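The source may report more compounds than this note shows. Statements on the series, on what has been measured and on what is new or still open speak of the compounds shown alone.

Compound 1 (`NC(=O)c1ccc(-c2cccnc2)cc1OC1CCC1`): in an assay on cells for inhibition of MAP kinase-interacting serine/threonine-protein kinase 1 (Homo sapiens), read by mobility shift assay, with stated times of 10 min and 60 min, in the presence of a further agent that is not named here (a lower number here means a stronger inhibitor, a higher number a weaker inhibitor), compound 1 gives 1900 nM
Compound 2 (`NC(=O)c1ccc(-c2cccnc2)cc1O`): in this assay compound 2 gives 4300 nM
Compound 3 (`NC(=O)c1ccc(-c2cccnc2)cc1OC1CCNC1`): in this assay compound 3 gives 1900 nM

For the measured compounds named here, compound 3 stands level with compound 1, the two together giving the lowest numbers of the three; the only step beyond the scatter is the one to compound 2, which shows a 2.3-fold lower number from compound 2 to compound 3 (0.35 log units; beyond the scatter). The step from compound 1 shows no change at the digits printed from compound 1 to compound 3 (within the scatter), so exchanging the cyclobutyl for pyrrolidin-3-yl on the oxygen on the aromatic ring made no difference that can be read.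

Compound 4 (`NC(=O)c1ccc(-c2cccnc2)cc1OC1CCCCC1`) carries the change (cyclohexyl in place of pyrrolidin-3-yl on an oxygen on an aromatic ring). Going by the values given here, two measured steps bear on it. The step of a 2.3-fold lower number from compound 2 to compound 3 (0.35 log units; beyond the scatter) shows that filling the position on the oxygen at all brings a modest gain over hydrogen, and the step of no change at the digits printed from compound 1 to compound 3 (within the scatter) shows that a carbon-only ring and a nitrogen-containing ring of similar size give the same number. Nothing measured here tells how a six-membered ring compares with a four- or five-membered one. Compound 4 is therefore expected to stay close to compound 3, with a step of a 1.1-fold lower number from compound 3 to compound 4 (0.02 log units; within the scatter) that lies within the scatter. The estimate for compound 4 in this assay is 1800 nM, between 700 nM and 4500 nM.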

Compound 4, half-maximal inhibitory concentration: 1500 nM
Estimate against measurement, compound 4: 1.2-fold (0.08 log units) above; the range from low to high includes it.
By their numbers in this assay, from the lowest: compounds 4, 1 and 3 (each within the scatter of the next); then compound 2.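

With cyclohexyl on the oxygen, the position accepts a six-membered ring of carbon only as well as the smaller rings: in this assay the step is a 1.3-fold lower number from compound 3 to compound 4 (0.10 log units; within the scatter) and, against the four-membered carbon ring, a 1.3-fold lower number from compound 1 to compound 4 (0.10 log units; within the scatter), so compounds 1, 3 and 4 cannot be told apart, and the exchange of pyrrolidin-3-yl for cyclohexyl, which removes the ring nitrogen along with its hydrogen-bond donor and acceptor, leaves no readable trace. For the compounds shown here, the one readable step remains the one from the free hydroxyl, a 2.9-fold lower number from compound 2 to compound 4 (0.46 log units; beyond the scatter), which is modest and places compound 4 with the other two ring ethers on the same side of compound 2. No measurement on these compounds offers an explanation for this flat response to ring size and ring nitrogen.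

From the compounds shown here alone, it remains open whether the gain over hydrogen needs a ring at all, as a methyl group or a longer open chain on the oxygen would show. Going by these compounds, it is equally open whether a cyclohexyl ring carrying an amine or a carboxylic acid would stay level with compound 4 or move away from it.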